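Swapping the Sugar for an Open Chain

The compounds below may be only part of what the source reports. "The series", "measured", "known", "first", "only" and "open" are said of these compounds alone.

Compound 1, with structure `NC(=O)c1nc(C#Cc2ccc(C(F)(F)F)cc2)n([C@@H]2O[C@H](CO)[C@@H](O)[C@H]2O)n1`, carries a carbamoyl group on its core and a 3,4-dihydroxy-5-(hydroxymethyl)oxolan-2-yl group on an aromatic nitrogen. In an ADME assay on cells (Homo sapiens) for cytotoxicity (on this read-out higher numbers stand for lower toxicity in this test and lower numbers for higher toxicity in this test), compound 1 reaches only a limit of the test, reported as > 120000 nM. Compound 2, `COC(=O)c1nc(C#CC2(O)CCCC2)n([C@@H]2O[C@H](COC(C)=O)[C@@H](OC(C)=O)[C@H]2OC(C)=O)n1`, bears a methyl ester, an acetylated sugar and a cyclopentanol on the alkyne. In this assay compound 2 likewise sits at a limit, given as > 105000 nM. Going by the values given here, the two recorded results are the limit of > 120000 nM in this assay, at which 1 of the 2 values shown sits, and (the limit of > 105000 nM in this assay, at which 1 of the 2 values shown sits), so no measured step between any two compounds is available, and neither compound can be placed above or below the other.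

Compound 3, `NC(=O)c1nc(C#Cc2ccc(C(F)(F)F)cc2)n(COCCO)n1`, differs from compound 1 by the change ((2-hydroxyethoxy)methyl in place of 3,4-dihydroxy-5-(hydroxymethyl)oxolan-2-yl on an aromatic nitrogen); in words, (2-hydroxyethoxy)methyl in place of 3,4-dihydroxy-5-(hydroxymethyl)oxolan-2-yl on an aromatic nitrogen. With both measured compounds showing only limits, no size for such a step can be read from the data. Compound 3 is expected to stay at a limit as well, with an expected step of a number no higher from compound 1 to compound 3 (the limit leaves the size open) that does not exceed the scatter. The estimate for compound 3 is 120000 nM, between 40000 nM and 300000 nM.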

Compound 3, half-maximal cytotoxic concentration: 79000 nM
Compound 3: the middle estimate sits 1.5-fold (0.18 log units) above what was measured, within the range that was stated.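

Going by these compounds alone, compound 3 gives the first value in this assay that is a number rather than a limit, which shows that a (2-hydroxyethoxy)methyl group on this aromatic nitrogen can give a measurable result on the shared core. Replacing the 3,4-dihydroxy-5-(hydroxymethyl)oxolan-2-yl group gives an at least 1.5-fold lower number from compound 1 to compound 3 (0.18 log units; that floor lies within the scatter), so the data establish no change beyond the scatter, although the true step may be larger. The value for compound 1 is a limit, which leaves only a floor for this step: the limit of > 120000 nM in this assay, at which 1 of the 3 values shown sits.

The swap removes the ring, the four defined stereocentres and hydrogen-bond donors and acceptors in a single change, so the compounds shown cannot tell which of these features matters in this assay. As far as these compounds go, it also remains open how a longer chain, or an amine in place of the terminal hydroxyl of the (2-hydroxyethoxy)methyl group, would read in this assay.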